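This account rests on a few compounds, and the source may have more. Where it says the series, first, only, none or still open, it means among the compounds named here.

Measured compounds:
compound 1 `N#CCN(Cc1ccc(Cl)cc1)Cc1ccc([N+](=O)[O-])s1`: 2500 nM
compound 2 `CCCCNC(=O)N1CCC(CN(Cc2ccc(Cl)cc2)Cc2ccc([N+](=O)[O-])s2)C1`: 670 nM

In a functional assay on HEK293 cells for agonist activity at nuclear receptor subfamily 1 group D member 1 (Homo sapiens), read by a luciferase reporter, with a stated time of 24 h (a higher number here means that more compound is needed for the effect, a lower number that less compound is needed), compound 1 gives 2500 nM and compound 2 gives 670 nM. Compound 2 has the lowest of the two numbers, and its gap to compound 1 is beyond the usual scatter. Compound 3 `CS(=O)(=O)N1CCC(CN(Cc2ccc(Cl)cc2)Cc2ccc([N+](=O)[O-])s2)C1` differs from compound 2 in one place: methylsulfonyl in place of butylcarbamoyl on an amine nitrogen in a ring. For the measured compounds named here, no measured pair shows this change, so its size is open. Because compound 1 gives 2500 nM with no cap at all, a small upward step is expected, a 2.2-fold higher number from compound 2 to compound 3 (0.35 log units; beyond the scatter). Compound 3 is expected to give about 1500 nM, between 500 nM and 5000 nM.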

Compound 3, half-maximal effective concentration: 570 nM
Compound 3: the middle estimate sits 2.6-fold (0.42 log units) above what was measured; the range from low to high includes it.
By their numbers in this assay, from the lowest: compounds 3 and 2 (each within the scatter of the next); then compound 1.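

On the amine nitrogen in the ring, methylsulfonyl can take the place of butylcarbamoyl without a real shift in this assay, with a 1.2-fold lower number from compound 2 to compound 3 (0.07 log units; within the scatter), even though the hydrogen-bond donor of butylcarbamoyl is gone. The larger replacement of cyano by 1-(methylsulfonyl)pyrrolidin-3-yl gives a 4.4-fold lower number from compound 1 to compound 3 (0.64 log units; beyond the scatter), so this capped ring holds its advantage with either cap. No measurement here explains these results.

As far as these compounds go, whether that ring nitrogen needs a cap at all remains open. So does whether a free amine, an acetyl group or a longer sulfonyl chain would serve there.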